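This account rests on a few compounds, and the source may have more. Where it says the series, first, only, none or still open, it means among the compounds named here.

Three compounds on the shared core have numbers in a functional assay on DU-145 cells (Homo sapiens) for inhibition, read by trypan blue exclusion, with a stated time of 72 h; on this read-out lower numbers stand for stronger inhibition and higher numbers for weaker inhibition: compound 1 (`Cn1c(=O)c(C(=O)Nc2ccc(F)cc2F)cc2cnc(Nc3ccc4[nH]ccc4c3)nc21`) gives 5000 nM, compound 2 (`Cn1c(=O)c(S(=O)(=O)c2ccc(F)cc2F)cc2cnc(Nc3cccc4[nH]ccc34)nc21`) gives 750 nM and compound 3 (`Cn1c(=O)c(S(=O)(=O)c2ccc(OC(=O)CCCCC3SCC4NC(=O)NC43)cc2)cc2cnc(Nc3ccc4[nH]ccc4c3)nc21`) gives 150 nM. Compound 2 therefore stands in the middle of the three, with compound 3 lower and compound 1 higher, and both gaps lie beyond the scatter. Going by the values given here, these three compounds offer no measured step that differs in one place only.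

Compound 4 (`Cn1ccc2cc(Nc3ncc4cc(S(=O)(=O)c5ccc(F)cc5F)c(=O)n(C)c4n3)ccc21`) departs from compound 2 in a single place: 1-methyl-1H-indol-5-yl in place of 1H-indol-4-yl on a nitrogen on an aromatic ring. The change is 1-methyl-1H-indol-5-yl in place of 1H-indol-4-yl on a nitrogen on an aromatic ring.

Among the compounds with values here, with no measured step to guide the direction, no shift beyond the scatter is expected in this assay, and the estimated change is a 1.1-fold lower number from compound 2 to compound 4 (0.03 log units; within the scatter). The expected range stays wide, since the measured values run from compound 3 at 150 nM to compound 1 at 5000 nM. For compound 4 the estimated value is 700 nM, with an expected range of 200 nM to 2500 nM.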

Compound 4, half-maximal inhibitory concentration: 750 nM
Compound 4: the middle estimate sits 1.1-fold (0.03 log units) below what was measured; low and high end bracket the measured number.
By their numbers in this assay, from the lowest: compound 3; then compounds 2 and 4 (each within the scatter of the next); then compound 1.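

First one-place step in the series: in this assay the move to 1-methyl-1H-indol-5-yl on a nitrogen on an aromatic ring reads no change at the digits printed from compound 2 to compound 4 (within the scatter). The entering group has 0 hydrogen-bond donors where the leaving group has 1, and it carries one more heavy atom, yet the number stays within the scatter, so at this position and in this compound the two groups cannot be told apart by this read-out. No supporting measurement bears on the reason for this result.

The step alters both the methyl and the indole attachment point, so a flat result cannot show how each acts alone, as opposing contributions would look the same. Also open, on these data alone, is how this assay responds at the same nitrogen to a group carrying an amine or a carboxylic acid, or a longer chain in place of the methyl.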